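This account rests on a few compounds, and the source may have more. Where it says the series, first, only, none or still open, it means among the compounds named here.

Compound 1 `Clc1ccccc1CSc1nnc(-c2ccncc2)n1-c1ccccc1`: 15700 nM
Compound 2 `c1ccc(CSc2nnc(-c3ccncc3)n2-c2ccccc2)cc1`: 12900 nM

Among the measured compounds shown here, in a functional assay on HepG2 cells (Homo sapiens) for inhibition, read by MTT assay, with a stated time of 48 h (a lower number here means a stronger inhibitor, a higher number a weaker inhibitor), compound 2 gives the lower of the two numbers measured so far, yet its only neighbour, compound 1, lies within the scatter of it, so the two cannot be told apart. Compound 3 `O=[N+]([O-])c1cccc(CSc2nnc(-c3ccncc3)n2-c2ccccc2)c1` differs from compound 2 in one place: nitro in place of hydrogen on an aromatic carbon, a nitro group in place of a hydrogen atom on the carbon-only six-membered ring, meta to a large group; cut one bond further out, phenyl becomes 3-nitrophenyl. For the measured compounds named here, the single measured step that touches this same ring is a 1.2-fold lower number from compound 1 to compound 2 (0.09 log units; within the scatter), where a chloro group left and nothing moved beyond the scatter. Going by the values given here, no measured step shows what a nitro group does here, so the expectation is no shift beyond the scatter, with a wide range. Compound 3 is therefore estimated at 12000 nM, between 5000 nM and 30000 nM. This estimate corresponds to an expected step of a 1.1-fold lower number from compound 2 to compound 3 (0.03 log units; within the scatter).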

Compound 3, half-maximal inhibitory concentration: 22000 nM
For compound 3 the middle estimate is 1.8-fold (0.26 log units) below the measured one, and the stated range covers the measured number.
By their numbers in this assay, from the lowest: compounds 2, 1 and 3 (each within the scatter of the next).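

In this assay, placing a nitro group on the phenyl ring gives a 1.7-fold higher number from compound 2 to compound 3 (0.23 log units; within the scatter) and so does not separate nitro from hydrogen at this carbon, even though three heavy atoms enter there. Exchanging the 2-chlorophenyl group for 3-nitrophenyl gives a 1.4-fold higher number from compound 1 to compound 3 (0.15 log units; within the scatter) and likewise stays within the scatter, so the plain phenyl, 2-chlorophenyl and 3-nitrophenyl groups of these three compounds cannot yet be told apart. No measurement is available that would explain this result.

The compounds shown leave open whether an amine or a carboxylic acid on this ring would move the number beyond the scatter. They also leave open whether a longer chain between the sulfur and the ring would do so.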